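The compounds below may be only part of what the source reports. "The series", "measured", "known", "first", "only" and "open" are said of these compounds alone.

Compound 1 `CCn1cc(C(CC)(CC)c2ccc(C#CC(O)(CC)CC)c(C)c2)cc1C(=O)OCCO` gives 12.6 nM in an assay on cells for agonist activity at vitamin D3 receptor (Homo sapiens), read by microscopy; on this read-out lower numbers stand for an effect already at smaller amounts and higher numbers for an effect only at larger amounts of compound. Compound 2 `CCCCC(=O)c1cc(C(CC)(CC)c2ccc(C#CC(O)(CC)CC)c(C)c2)cn1CC` is read only as a limit, > 50 nM, in this assay. The step of an at least 3.9-fold higher number from compound 1 to compound 2 (0.59 log units; beyond the scatter) is thus open-ended, bounded by the limit of > 50 nM in this assay, at which 1 of the 2 values shown sits. Compound 3 `CCn1cc(C(CC)(CC)c2ccc(C#CC(O)(CC)CC)c(C)c2)cc1C(=O)NCC(=O)O` differs from compound 2 by (carboxymethyl)amino in place of butyl on a carbonyl carbon. For the measured compounds named here, the sole measured step, an at least 3.9-fold higher number from compound 1 to compound 2 (0.59 log units; beyond the scatter), exchanged 2-hydroxyethoxy for butyl and moved beyond the scatter; the present change runs the other way, putting a group carrying hydrogen-bond donors in place of butyl, and is the nearest guide. Compound 3 is therefore expected to land on the potent side of that limit, a step of an at least 1.6-fold lower number from compound 2 to compound 3 (0.22 log units; that floor lies within the scatter), at an estimated 30 nM (8 nM to 120 nM) in this assay.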

Compound 3, half-maximal effective concentration: 54.3 nM
Compound 3: the middle estimate sits 1.8-fold (0.26 log units) below what was measured; the range from low to high includes it.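

In this assay, (carboxymethyl)amino on this carbonyl carbon does not match 2-hydroxyethoxy, with a 4.3-fold higher number from compound 1 to compound 3 (0.63 log units; beyond the scatter). Hydrogen-bond donors in the group on the carbonyl carbon are therefore not enough on their own to keep the number of compound 1. Compound 2 stands only as a limit, so the step from it to compound 3 cannot be read: the limit of > 50 nM in this assay, at which 1 of the 3 values shown sits.

Open, on these data alone, is whether the amide link or the carboxylic acid end of (carboxymethyl)amino accounts for the step from compound 1. A 2-hydroxyethylamino group on the same carbonyl carbon would separate the two.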